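Swapping Bromo for Chloro in a Weakly Cytotoxic Series

The source may hold more compounds than are shown below. What is called first, only, known or untested is meant among the compounds shown, and "the series" means these compounds.

Three compounds have been examined in an ADME assay on Vero cells (Chlorocebus sabaeus) for cytotoxicity, read by MTT assay, with a stated time of 72 h; on this read-out lower numbers stand for stronger inhibition and higher numbers for weaker inhibition. Compound 1 `Brc1ccc(-c2nnc(-c3ccc(-n4cccc4)cc3)o2)cc1` gives 260000 nM in this assay. Compound 2 `CC(=O)N1N=C(c2ccc(-n3c(C)ccc3C)cc2)OC1c1ccc(Br)cc1` gives 195000 nM, and compound 3 `CC(=O)NNC(=O)c1ccc(-n2c(C)ccc2C)cc1` gives 173000 nM. Compound 1 carries the highest of the three numbers, yet both of the others fall within the usual scatter of it, so the three compounds cannot be separated on these figures, and all of them sit at the weak end of the read-out.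

Compound 4 `Clc1ccc(-c2nnc(-c3ccc(-n4cccc4)cc3)o2)cc1` has not yet been measured. It differs from compound 1 in a single respect: chloro in place of bromo on an aromatic carbon. The remainder of the shared core of compound 1 is unchanged. For the measured compounds named here, no pair of measured compounds differs in just one place, so there is no measured step in this set to lean on. An exchange of one atom for another, with no change in donors, acceptors or charge, offers little ground for expecting movement, and compound 1 already stands at 260000 nM. Compound 4 is therefore expected to show a step of a 1.0-fold lower number from compound 1 to compound 4 (0.02 log units; within the scatter), which is none beyond the scatter. The estimate for compound 4 is 250000 nM, with a range from 120000 nM to 520000 nM.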

Compound 4, half-maximal inhibitory concentration: 253000 nM
The estimate for compound 4 lay 1.0-fold (0.01 log units) below the measured number; the range from low to high includes it.
By their numbers in this assay, from the lowest: compounds 3, 2, 4 and 1 (each within the scatter of the next).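

For the compounds shown here, the exchange of 4-bromophenyl to 4-chlorophenyl supplies the only measured step in this set between compounds that differ in one place: in this assay, the step is a 1.0-fold lower number from compound 1 to compound 4 (0.01 log units; within the scatter). At this position on the six-membered aromatic ring, para to a large group, chloro and bromo therefore cannot be told apart on this read-out, and compound 4, at 253000 nM, remains at the weak end of it, as compound 1 does. Nothing measured alongside this result indicates why the two halogens read alike.

The compounds shown leave open whether this position responds to anything other than a halogen, since an amine, a carboxylic acid or a longer chain on the same aromatic carbon could read alike or could move the number beyond the scatter. They also leave open whether the same exchange of bromo for chloro would read alike in compound 2, which carries the 4-bromophenyl group on a different core.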